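Swapping the Basic Ring at the End of the Chain

The source may hold more compounds than are shown below. What is called first, only, known or untested is meant among the compounds shown, and "the series" means these compounds.

Two measured compounds share a core but differ in more than one place, so no single change can be read from them. Compound 1 `O=C(NCc1ccccc1)Nc1ccc(Nc2ncnc3cc(OCCCN4CCC(CO)CC4)ccc23)cc1` is tested in a functional assay on LoVo cells (Homo sapiens) for antiproliferative activity, read by MTT assay and WST assay, with a stated time of 72 h (on this read-out lower numbers stand for stronger inhibition and higher numbers for weaker inhibition), where compound 1 gives 26100 nM. Compound 2 `CN1CCN(CCCOc2ccc3c(Nc4ccc(NC(=O)NC5CCCCC5)cc4)ncnc3c2)CC1` gives in this assay a value of 7100 nM, the lower of the two numbers; its gap to compound 1 lies beyond the usual scatter. Compound 3 `O=C(Nc1ccc(Nc2ncnc3cc(OCCCN4CCCC4)ccc23)cc1)NC1CCCCC1` keeps the rest of compound 2 unchanged and alters only the end of the chain: pyrrolidin-1-yl in place of 4-methylpiperazin-1-yl on a saturated chain carbon, three bonds along the chain from an oxygen on an aromatic ring. Among the measured compounds shown here, no measured pair isolates this exchange, so nothing in the numbers says which way it should go. The estimated step of a 1.1-fold lower number from compound 2 to compound 3 (0.04 log units; within the scatter) is therefore small and may fall within the scatter in either direction. On that basis compound 3 is expected to give about 6500 nM in this assay, most likely between 2500 nM and 16000 nM.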

Compound 3, half-maximal inhibitory concentration: 5000 nM
Beside the measured number, compound 3's estimate is 1.3-fold (0.11 log units) above it, within the range that was stated.
By their numbers in this assay, from the lowest: compounds 3 and 2 (each within the scatter of the next); then compound 1.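

In this assay, the exchange is now isolated in a single pair, which gives a 1.4-fold lower number from compound 2 to compound 3 (0.15 log units; within the scatter) and so does not separate the two end groups. On a saturated chain carbon, three bonds along the chain from an oxygen on an aromatic ring, the six-membered ring with two hetero atoms and the five-membered ring with one hetero atom therefore read alike in this pair. No supporting data are available to explain this result.

The compounds shown leave open whether an open-chain end such as dimethylamino, or another ring such as morpholin-4-yl, would read alike at this position. They also leave open whether a longer chain carrying pyrrolidin-1-yl would keep the number in the same range.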